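A few compounds are considered here, and "the series" means these few. Any claim that something is new, unique, unknown or untested is made for them only; others in the source may bear on it.

Compound 1 `COc1ccc(/C=C/C(=O)Nc2cc3c(Nc4ccc(Cl)c(Cl)c4)ncnc3s2)cc1` and compound 2 `O=C(/C=C/c1ccccc1)Nc1cc2c(Nc3ccc(Cl)c(Cl)c3)ncnc2s1` share one core and differ at a single spot. In a functional assay on HeLa cells (Homo sapiens) for antiproliferative activity, read by MTT assay, with a stated time of 48 h (on this read-out lower numbers stand for stronger inhibition and higher numbers for weaker inhibition), compound 1 gives 33 nM, while compound 2 gives 430 nM. That is a 13-fold lower number from compound 2 to compound 1 (1.11 log units; beyond the scatter), the change being (methoxy in place of hydrogen on an aromatic carbon). Compound 3 `O=C(/C=C/c1ccccc1)Nc1cc2ncnc(Nc3ccc(F)c(Cl)c3)c2s1` carries a different core; the difference between the two cores is not broken down here. In this assay compound 3 gives 2810 nM, the highest number of the three. Compound 4 `COc1ccc(/C=C/C(=O)Nc2cc3ncnc(Nc4ccc(F)c(Cl)c4)c3s2)cc1` has not yet been measured; it differs from compound 3 by methoxy in place of hydrogen on an aromatic carbon, the same change at the same place as between compound 2 and compound 1. The earlier change read a 13-fold lower number from compound 2 to compound 1 (1.11 log units; beyond the scatter), so for compound 4 the expected step, allowing that a new core may carry it only in part, is an 8.0-fold lower number from compound 3 to compound 4 (0.90 log units; beyond the scatter). Compound 4 is therefore estimated at 350 nM, likely between 100 nM and 1200 nM.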

Compound 4, half-maximal inhibitory concentration: 20600 nM
Beside the measured number, compound 4's estimate is 59-fold (1.77 log units) below it, outside the stated range (above it).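

In this assay, the same methoxy change weakens inhibition on this core, giving a 7.3-fold higher number from compound 3 to compound 4 (0.87 log units; beyond the scatter). The phenyl to 4-methoxyphenyl change therefore does not carry over from one core to the other, and its direction reverses: the same change on two cores in this assay, a 13-fold lower number (1.11 log units; beyond the scatter) from compound 2 to compound 1 and a 7.3-fold higher number (0.87 log units; beyond the scatter) from compound 3 to compound 4, 96-fold (1.98 log units) apart, beyond the scatter of two such steps. For the compounds shown here, this shows that a gain seen on the core of compound 1 cannot be assumed on the core of compound 3, but with only one pair on each core, it does not show which difference between the cores lies behind the reversal.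

As far as these compounds go, it remains open whether an ethoxy group, a hydroxyl group or an amine at the same place would also pull the two cores in opposite directions. A carboxylic acid there is equally unresolved.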